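Swapping the aryl group on the triazole for a short chloroalkyl chain

A few compounds are considered here, and "the series" means these few. Any claim that something is new, unique, unknown or untested is made for them only; others in the source may bear on it.

Measured so far:
- compound 1, `O=C1O[C@H]([C@@H](O)Cn2cc(-c3cc(C(F)(F)F)cc(C(F)(F)F)c3)nn2)C(OCc2ccccc2)=C1OCc1ccccc1`: 57200 nM
- compound 2, `CCCCCc1ccc(-c2cn(C/C=C3\OC(=O)C(OCc4ccccc4)=C3OCc3ccccc3)nn2)cc1`: > 100000 nM
- compound 3, `CCCCCc1ccc(-c2cn(C[C@H](O)[C@H]3OC(=O)C(OCc4ccccc4)=C3OCc3ccccc3)nn2)cc1`: 13800 nM

All three share a core built around a furanone that carries two benzyloxy groups and a triazole-bearing side chain. In a functional assay on HCT-116 cells (Homo sapiens) for antiproliferative activity, read by MTT assay, with a stated time of 72 h (a higher number here means a weaker inhibitor, a lower number a stronger inhibitor), compound 3 gives 13800 nM, the lowest of the two numbers recorded. Compound 1 gives 57200 nM, a higher number, and the gap between compound 1 and compound 3 lies beyond the usual scatter. For compound 2 the result is only a limit, > 100000 nM, and the same limit appears as the limit of > 100000 nM in this assay, at which 1 of the 3 values shown sits.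

Compound 4, `O=C1O[C@H]([C@@H](O)Cn2cc(CCCCl)nn2)C(OCc2ccccc2)=C1OCc1ccccc1`, has not been measured. It differs from compound 3 in one place: 3-chloropropyl in place of 4-pentylphenyl on an aromatic carbon. For the measured compounds named here, no pair of measured compounds shows this kind of change, so its effect has to be guessed. Compound 4 is expected to be a weaker inhibitor than compound 3, with an estimated step of a 2.9-fold higher number from compound 3 to compound 4 (0.46 log units; beyond the scatter) in this assay. The estimate for compound 4 is 40000 nM, expected to fall between 12000 nM and 100000 nM.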

Compound 4, half-maximal inhibitory concentration: 36100 nM
For compound 4 the middle estimate is 1.1-fold (0.04 log units) above the measured one; measured number inside the range.
By their numbers in this assay, from the lowest: compound 3; then compounds 4 and 1 (each within the scatter of the next). At a limit, above all of these: compound 2.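

Replacing the 4-pentylphenyl group with 3-chloropropyl on this carbon of the triazole removes the benzene ring and leaves a much smaller group, yet in this assay the change costs only a 2.6-fold higher number from compound 3 to compound 4 (0.42 log units; beyond the scatter) and the activity remains measurable. This position therefore does not need an aromatic ring for a measurable effect on the cells, although compound 3 keeps a real edge over compound 4. Compound 4 and compound 1 lie within the scatter of each other, so having an aryl group here does not by itself give a lower number than the chloroalkyl chain.

On these data alone, it remains open whether the ring, the chain length or the chlorine accounts for the step, which a plain pentyl chain or a propyl chain ending in an amine could help separate. Nothing measured here gives a reason for the step.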